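The compounds below may be only part of what the source reports. "The series", "measured", "known", "first", "only" and "open" are said of these compounds alone.

For the measured compounds named here, compound 2 `O=S(=O)(NCCCNCc1ccc(C(F)(F)F)cc1)c1cc(C(F)(F)F)cc(C(F)(F)F)c1` gives the higher of the two numbers so far in a functional assay on HT-29 cells (Homo sapiens) for inhibition, read by MTT assay, with a stated time of 72 h (on this read-out higher numbers stand for weaker inhibition of growth and lower numbers for stronger inhibition of growth), at 2900 nM. Compound 1 `O=S(=O)(NCCCNCC1COc2ccccc2O1)c1cc(C(F)(F)F)cc(C(F)(F)F)c1`, which differs from it only in the group on the chain carbon bound to the amine nitrogen, gives 2200 nM in this assay, and the change a 1.3-fold higher number from compound 1 to compound 2 (0.12 log units; within the scatter) lies within the scatter, so the two compounds cannot be ranked against each other. Compound 3 `O=S(=O)(NCCCNCc1ccc(-c2ccccc2)cc1)c1cc(C(F)(F)F)cc(C(F)(F)F)c1` is not yet measured. Relative to compound 2 it carries phenyl in place of trifluoromethyl on an aromatic carbon. Going by the values given here, no measured step touches this position; the single known step concerns a different part of the molecule and was itself within the scatter, so there is nothing in the data that points to a shift beyond the scatter in either direction. The number for compound 3 in this assay is therefore expected to be close to that of compound 2, with the step of a 1.2-fold lower number from compound 2 to compound 3 (0.06 log units; within the scatter) estimated as no change beyond the scatter. On that basis compound 3 is estimated at 2500 nM, with a range from 800 nM to 8000 nM.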

Compound 3, concentration for 50% growth inhibition: 2300 nM
Compound 3: middle estimate off by 1.1-fold (0.04 log units), on the high side, and the stated range covers the measured number.
By their numbers in this assay, from the lowest: compounds 1, 3 and 2 (each within the scatter of the next).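

In this assay, for the compounds shown here, the step of a 1.3-fold lower number from compound 2 to compound 3 (0.10 log units; within the scatter) is the first reading at this position, on an aromatic carbon para to a large group. It shows that exchanging trifluoromethyl, which has no ring, for phenyl, a six-membered aromatic ring of carbon only, gives no change beyond the scatter, so compound 2 and compound 3 cannot be ranked against each other. No evidence on the cause accompanies this result.

On these data alone, whether an amine or a carboxylic acid on this same aromatic carbon would shift the number beyond the scatter remains open. The compounds shown also leave open whether a longer chain in the shared core would do so.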